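This account rests on a few compounds, and the source may have more. Where it says the series, first, only, none or still open, it means among the compounds named here.

Compound 1 `O=C(/C(=C\c1ccccc1F)S(=O)(=O)c1ccc(Br)cc1)c1ccc(Cl)cc1` gives 25000 nM in a functional assay on DU-145 cells (Homo sapiens) for inhibition, read by trypan blue exclusion, with a stated time of 96 h; on this read-out higher numbers stand for weaker inhibition of growth and lower numbers for stronger inhibition of growth. Compound 2 `Cc1ccc(S(=O)(=O)/C(=C/c2ccccc2F)C(=O)c2ccc(Cl)cc2)cc1` gives 2500 nM in this assay. Compound 3 `Cc1ccsc1/C=C(/SCc1ccc(Cl)c(Cl)c1)C(=O)c1ccc(Cl)cc1` gives 50000 nM in this assay.

Compound 2 stands at the lowest of these three numbers, which on this read-out means the strongest growth inhibition. Among the compounds with values here, the one measured step that changes a single place is a 10-fold lower number from compound 1 to compound 2 (1.00 log units; beyond the scatter), a methyl in place of bromo on an aromatic carbon. Compound 3 differs from the others at several places at once, so only its number can be compared, and it is the highest of the three.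

Compound 4 `Cc1ccc(S(=O)(=O)/C(=C/c2ccc(O)c([N+](=O)[O-])c2)C(=O)c2ccc(Cl)cc2)cc1` differs from compound 2 by 4-hydroxy-3-nitrophenyl in place of 2-fluorophenyl on a double-bonded chain carbon bound to a double-bonded chain carbon. Within the data shown here, no measured step bears on this change: the one step available swaps a small group on a ring, not the whole ring attached to the chain. With nothing to point in either direction, no step beyond the scatter is expected, though the uncertainty is wide. The expected outcome for compound 4 is therefore no change at the digits printed from compound 2 to compound 4 (within the scatter), giving an estimate of 2500 nM with a range from 600 nM to 12000 nM.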

Compound 4, concentration for 50% growth inhibition: 25000 nM
Beside the measured number, compound 4's estimate is 10-fold (1.00 log units) below it, and the stated range ends below it.
By their numbers in this assay, from the lowest: compound 2; then compounds 1, 4 and 3 (each within the scatter of the next).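

The earlier compounds shown here showed a change only at a small group elsewhere on the molecule, whereas this result shows that the whole ring on the double-bonded chain carbon also matters in this assay. Replacing that ring brings a 10-fold higher number from compound 2 to compound 4 (1.00 log units; beyond the scatter), so growth inhibition weakens with this change. Nothing measured here gives a reason for the shift.

This single step cannot separate the hydroxy group, the nitro group and the lost fluorine from one another. As far as these compounds go, how a ring carrying an amine or a methoxy group would behave at this place remains open.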